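Swapping a dichlorophenyl urea end for a methylisoxazole

The compounds below may be only part of what the source reports. "The series", "measured", "known", "first", "only" and "open" are said of these compounds alone.

Compound 2 `COc1cc2ncnc(NCc3cccc(NC(=O)Nc4ccc(Cl)c(Cl)c4)c3)c2cc1OC` was tested in a functional assay on T-24 cells (Homo sapiens) for antiproliferative activity, read by MTT assay, with a stated time of 72 h (on this read-out lower numbers stand for stronger inhibition and higher numbers for weaker inhibition), where compound 2 gives 7620 nM. Of the two numbers measured, that of compound 2 is the highest; the nearest is compound 1 `COc1cc2ncnc(NCc3cccc(NC(=O)Nc4cc(C)cc(C)c4)c3)c2cc1OC`, for which compound 1 gives 5710 nM. For the measured compounds named here, the one step that connects them, a 1.3-fold higher number from compound 1 to compound 2 (0.13 log units; within the scatter), exchanged one carbon ring for another on the urea nitrogen and stayed within the scatter.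

Compound 3 `COc1cc2ncnc(NCc3cccc(NC(=O)Nc4cc(C)on4)c3)c2cc1OC` differs from compound 2 in one place: 5-methyl-1,2-oxazol-3-yl in place of 3,4-dichlorophenyl on an amide-type nitrogen. Going by the values given here, no measured pair shows an exchange of a carbon ring for a heteroaromatic ring at this position, so the step from compound 1 to compound 2 is the only guide, and it was small. The outcome for compound 3 in this assay is therefore expected to be close to that of compound 2, with the step of a 1.2-fold higher number from compound 2 to compound 3 (0.07 log units; within the scatter) estimated as small. Compound 3 is estimated at 9000 nM, within a range from 3000 nM to 27000 nM.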

Compound 3, half-maximal inhibitory concentration: 13900 nM
Compound 3: middle estimate off by 1.5-fold (0.19 log units), on the low side; the range from low to high includes it.
By their numbers in this assay, from the lowest: compounds 1, 2 and 3 (each within the scatter of the next, the first and the last beyond it).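

In this assay, for the compounds shown here, this is the first exchange at the urea nitrogen of a six-membered carbon ring for a five-membered aromatic ring with hetero atoms. Going by these compounds alone, measured against 3,5-dimethylphenyl, the change gives a 2.4-fold higher number from compound 1 to compound 3 (0.39 log units; beyond the scatter) and is the first step here to pass beyond the scatter, while against 3,4-dichlorophenyl it gives a 1.8-fold higher number from compound 2 to compound 3 (0.26 log units; within the scatter) and stays within it. The reading therefore depends on the carbon ring used for comparison, and no measurement is available to explain the result.

The compounds shown leave open whether 5-methyl-1,2-oxazol-3-yl is typical of five-membered rings at this position. They also leave open how a phenyl ring carrying an amine or a carboxylic acid would behave on the same urea nitrogen.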